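A few compounds are considered here, and "the series" means these few. Any claim that something is new, unique, unknown or untested is made for them only; others in the source may bear on it.

In a functional assay on HCT-116 cells (Homo sapiens) for antiproliferative activity, read by MTT assay, with a stated time of 48 h (on this read-out lower numbers stand for stronger inhibition and higher numbers for weaker inhibition), compound 1 (`CCCCCCC(CCO)n1cnc2c(Cl)ncnc21`) gives 11900 nM and compound 2 (`C=C(CO)C(CCCCCC)n1cnc2c(Cl)ncnc21`) gives 30200 nM, the higher of the two numbers and so the weaker inhibition. Compound 3 (`C=C(CO)C(CCCCCCCC)n1cnc2c(Cl)ncnc21`) differs from compound 2 only in its chain: ethyl in place of hydrogen on a saturated chain carbon, seven bonds along the chain from an aromatic nitrogen and a double-bonded chain carbon. For the measured compounds named here, the one measured step, a 2.5-fold higher number from compound 1 to compound 2 (0.40 log units; beyond the scatter), is modest and concerns a different group, so it offers a rough sense of size but no direction for a longer chain. With no direction available, the estimated change is small: a 1.3-fold lower number from compound 2 to compound 3 (0.10 log units; within the scatter). For compound 3 the expected value is 24000 nM, with an estimated range of 9000 nM to 55000 nM.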

Compound 3, half-maximal inhibitory concentration: 19400 nM
Compound 3: the middle estimate sits 1.2-fold (0.09 log units) above what was measured; measured number inside the range.
By their numbers in this assay, from the lowest: compounds 1, 3 and 2 (each within the scatter of the next, the first and the last beyond it).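

Ethyl in place of hydrogen on a saturated chain carbon, seven bonds along the chain from an aromatic nitrogen and a double-bonded chain carbon, gives a 1.6-fold lower number from compound 2 to compound 3 (0.19 log units; within the scatter) in this assay. This is the only step shown that alters the chain itself, and it leaves compound 2 and compound 3 indistinguishable in this measurement, so adding ethyl at this place has no clear effect on the read-out. No measurement shown offers an explanation for this result. On these data alone, whether a longer chain, or a chain carrying an amine or a carboxylic acid, would separate clearly from compound 2 stays open.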